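This account rests on a few compounds, and the source may have more. Where it says the series, first, only, none or still open, it means among the compounds named here.

Of the compounds shown here, three sharing one core have been tested in an ADME assay on ECV-304 cells (Homo sapiens) for cytotoxicity, read by MTT assay, with a stated time of 72 h; on this read-out lower numbers stand for stronger inhibition and higher numbers for weaker inhibition. Compound 1 `COc1ccc(C2=C(c3cc(OC)c(OC)c(OC)c3)C(=O)CC2C)cc1C(=O)O` gives > 100 ug/mL, which is a limit of the assay rather than a number. Compound 2 `COc1ccc(C2=C(c3cc(OC)c(OC)c(OC)c3)C(=O)CC2O)cc1` gives > 100 ug/mL, again only a limit. Compound 3 `COc1ccc(C2=C(c3cc(OC)c(OC)c(OC)c3)C(=O)C(O)C2)cc1` gives < 1 ug/mL, also a limit. Compound 2 thus stands at the weaker end, where two of the three values sit (the limit of > 100 ug/mL in this assay, at which 2 of the 3 values shown sit), while one value sits at the limit of < 1 ug/mL in this assay, at which 1 of the 3 values shown sits. Compound 4 `CCOC(=O)COc1ccc(C2=C(c3cc(OC)c(OC)c(OC)c3)C(=O)CC2O)cc1` differs from compound 2 by ethoxycarbonyl in place of hydrogen on a saturated chain carbon bound to an oxygen on an aromatic ring. For the measured compounds named here, no measured step of this kind is available, so the direction is open; a modest move toward stronger inhibition, or none beyond the scatter, is expected in this assay. Compound 4 is therefore expected to give about 80 ug/mL, within 10 ug/mL to 300 ug/mL. The expected step is an at least 1.2-fold lower number from compound 2 to compound 4 (0.09 log units; that floor lies within the scatter).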

Compound 4, half-maximal inhibitory concentration: > 100 ug/mL
Compound 4 was reported as a limit; the forecaster's own chance of this, stated with the estimate: 60%; middle value at least 1.2-fold (0.09 log units) away from the limit.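

For the compounds shown here, compound 2 and compound 4 are both reported only as limits in this assay, so no step between them can be read. As far as these compounds go, whether ethoxycarbonyl in place of hydrogen shifts the value in either direction stays open.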